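Chain extension on the ring-expanded core, compound 3 to compound 4

The compounds below may be only part of what the source reports. "The series", "measured", "known", "first", "only" and "open" are said of these compounds alone.

Compound 1 `O=C(O)CCC[C@H]1CC[C@@H]2[C@@H](/C=C/[C@@H](O)COc3ccccc3)[C@H](O)C[C@@H]2O1` gives 7.1 nM in a functional assay on CHO cells for agonist activity at prostaglandin F2-alpha receptor (Homo sapiens), read by fluorescence and calcium flux; a higher number here means that more compound is needed for the effect, a lower number that less compound is needed. Compound 2 `O=C(O)CC[C@@H]1CC[C@@H]2[C@@H](/C=C/[C@@H](O)COc3ccccc3)[C@H](O)C[C@@H]2OC1` gives 1000 nM, and compound 3 `O=C(O)CC[C@H]1CC[C@@H]2[C@@H](/C=C/[C@@H](O)COc3ccccc3)[C@H](O)C[C@@H]2OC1` gives 110 nM, the second highest of the three numbers; compound 1 shows the lowest of the three. Within the data shown here, the one measured step, a 9.1-fold lower number from compound 2 to compound 3 (0.96 log units; beyond the scatter), rests on the fact that compounds 2 and 3 differ only in the configuration as drawn and concerns configuration alone.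

Compound 4 `O=C(O)CCC[C@H]1CC[C@@H]2[C@@H](/C=C/[C@@H](O)COc3ccccc3)[C@H](O)C[C@@H]2OC1` is not yet measured. It differs from compound 3 by carboxymethyl in place of carboxy on a saturated chain carbon, two bonds along the chain from a saturated ring carbon. Among the measured compounds shown here, no measured step bears on this change: the step from compound 2 to compound 3 changes configuration, not chain length, and compound 1 differs from compound 3 in two places at once, so its value shows only that a longer chain on another core can go with a low number. The expectation for compound 4 is therefore a step of uncertain direction, held near the scatter, a 1.8-fold lower number from compound 3 to compound 4 (0.26 log units; within the scatter). Compound 4 is estimated at 60 nM, within 15 nM to 250 nM.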

Compound 4, half-maximal effective concentration: 28 nM
For compound 4 the middle estimate is 2.1-fold (0.33 log units) above the measured one; measured number inside the range.
By their numbers in this assay, from the lowest: compound 1; then compound 4; then compound 3; then compound 2.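

Chain length at this position now has a measured effect of its own: carboxymethyl in place of carboxy, on a saturated chain carbon, gives a 3.9-fold lower number from compound 3 to compound 4 (0.59 log units; beyond the scatter) in this assay. Among these compounds, the earlier steps on this core covered configuration alone, so this is the only reading on chain length, and it shows that the extension on the core of compound 3 moves the number in the same direction as the low value of compound 1 had left possible. Nothing at hand accounts for the size or direction of this step.

On these data alone, compound 1 gives 7.1 nM and compound 4 gives 28 nM, so compound 1 still shows the lower number, and whether that gap can be narrowed on the core of compound 4 stays open. Also open, as far as these compounds go, is whether a longer chain such as 4-carboxybutyl continues the change, or whether an amide can stand in place of the carboxylic acid.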